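Furan-2-yl for phenyl: compounds 1 to 3

This account rests on a few compounds, and the source may have more. Where it says the series, first, only, none or still open, it means among the compounds named here.

Measured so far:
- compound 1 `CCOC(=O)c1nn(-c2ccc(Cl)cc2)/c(=N/c2nc(-c3c(C)n(C)n(-c4ccccc4)c3=O)cs2)s1`, in a functional assay on HepG2 cells (Homo sapiens) for cytotoxicity, read by sulforhodamine B assay, with a stated time of 72 h (on this read-out lower numbers stand for stronger inhibition and higher numbers for weaker inhibition), gives > 100000 nM, a limit of the assay.
- compound 2 `Cc1c(-c2csc(/N=C3\S/C(=C\c4ccccc4)C(=O)N3c3ccccc3)n2)c(=O)n(-c2ccccc2)n1C`, in this assay gives 63400 nM.

Going by the values given here, compound 2 holds the only number in this assay; the other entry is a limit, as recorded for compound 1 (the limit of > 100000 nM in this assay, at which 1 of the 2 values shown sits). Compound 1 carries a different set of groups and is not linked to compound 2 by any single-point step, so only the two values themselves are compared, and no size or cause is attached to the gap between them.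

Compound 3 `Cc1c(-c2csc(/N=C3\S/C(=C\c4ccco4)C(=O)N3c3ccccc3)n2)c(=O)n(-c2ccccc2)n1C` differs from compound 2 in one place: furan-2-yl in place of phenyl on a double-bonded chain carbon bound to a double-bonded ring carbon. Both rings are aromatic and the substituent sits on the same chain carbon.

Among the compounds with values here, no measured step covers this kind of exchange in this assay, so the expectation rests on compound 2 alone. The change from compound 2 to compound 3 is expected to be a 1.1-fold lower number from compound 2 to compound 3 (0.02 log units; within the scatter), that is, no shift beyond the usual scatter in either direction. Compound 3 is therefore estimated at 60000 nM, with a range from 25000 nM to 150000 nM.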

Compound 3, half-maximal inhibitory concentration: 16700 nM
Beside the measured number, compound 3's estimate is 3.6-fold (0.56 log units) above it, outside the stated range (below it).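

In this assay, the double-bonded chain carbon bound to a double-bonded ring carbon is now shown to respond to a change of aromatic ring, since furan-2-yl in place of phenyl gives a 3.8-fold lower number from compound 2 to compound 3 (0.58 log units; beyond the scatter) in this series. Going by these compounds alone, this is the first single-point step available, and it turns two unconnected values into a reading of one position: a five-membered aromatic ring with one hetero atom and one hydrogen-bond acceptor, in place of a six-membered carbon ring with none, is enough to move the number beyond the scatter, although the step remains modest. Within the data shown here, nothing measured so far accounts for the size or direction of this step.

The two rings compared leave open whether the lower number is particular to furan-2-yl or would also come with thiophen-2-yl, pyridin-2-yl, or a non-aromatic group such as cyclohexyl or a short alkyl chain at the same place. Also open, going by these compounds, is whether the step would carry over to the core of compound 1, whose entry in this assay is only a limit, or to other groups on the shared core of compound 2 and compound 3.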